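The source may report more compounds than this note shows. Statements on the series, on what has been measured and on what is new or still open speak of the compounds shown alone.

In an assay on isolated protein with dual specificity calcium/calmodulin-dependent 3',5'-cyclic nucleotide phosphodiesterase 1B (Bos taurus) as the target, tested at 100 uM (a higher number here means more inhibition at the concentration tested (going by the name of the read-out), a lower number less inhibition), three compounds have been measured so far:

Compound 1 `Nc1nc2c(c(=O)n(CC3CC3)c(=O)n2CC2CC2)n1S(=O)(=O)c1ccc(Cl)cc1` gives 1%.
Compound 2 `COc1ccc(S(=O)(=O)n2c(N)nc3c2c(=O)n(CC2CC2)c(=O)n3CC2CC2)cc1` gives 25%.
Compound 3 `COc1ccc(OC)c(S(=O)(=O)n2c(N)nc3c2c(=O)n(CC2CC2)c(=O)n3CC2CC2)c1` gives 31%.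

Compound 3 stands highest of the three numbers; its nearest neighbour is compound 2, and the gap a number 6 percentage points higher from compound 2 to compound 3 (within the scatter) lies within the scatter, while the gap to compound 1, a number 30 percentage points higher from compound 1 to compound 3 (beyond the scatter), lies beyond it. Compound 4 `COc1ccc(S(=O)(=O)n2c(N)nc3c2c(=O)n(CC2CC2)c(=O)n3CC2CC2)cc1OC` differs from compound 3 by 3,4-dimethoxyphenyl in place of 2,5-dimethoxyphenyl on a sulfonyl sulfur. Among the compounds with values here, no measured step rearranges the methoxy groups on the ring, so the steps that bear on it are indirect: a number 24 percentage points higher from compound 1 to compound 2 (beyond the scatter) and a number 30 percentage points higher from compound 1 to compound 3 (beyond the scatter) show that rings carrying methoxy sit above the chloro-bearing ring, and a number 6 percentage points higher from compound 2 to compound 3 (within the scatter) shows that a second methoxy changed little. The step in this assay is therefore expected to stay within the scatter, a number 3 percentage points lower from compound 3 to compound 4 (within the scatter). Compound 4 is estimated at 28%, within 10% to 46%.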

Compound 4, a percentage reported as inhibition, at one concentration (the size of the read-out at that concentration, not a potency): 56%
Estimate against measurement, compound 4: 28 percentage points below, and the stated range ends below it.
By their numbers in this assay, from the lowest: compound 1; then compounds 2 and 3 (each within the scatter of the next); then compound 4.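

Swapping 2,5-dimethoxyphenyl for 3,4-dimethoxyphenyl on the sulfonyl sulfur gives a number 25 percentage points higher from compound 3 to compound 4 (beyond the scatter) in this assay, so with the same atoms, the arrangement of the methoxy groups matters and not only their number. A second methoxy can therefore count: methoxy in place of hydrogen gives a number 31 percentage points higher from compound 2 to compound 4 (beyond the scatter), and the full ring change gives a number 55 percentage points higher from compound 1 to compound 4 (beyond the scatter). No supporting data explain why the arrangement matters. From the compounds shown here alone, it remains open whether ethoxy or an amine on this ring would match methoxy, and whether a single methoxy in another place would suffice.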